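The source may report more compounds than this note shows. Statements on the series, on what has been measured and on what is new or still open speak of the compounds shown alone.

In an ADME assay on Vero cells (Chlorocebus sabaeus) for cytotoxicity, read by resazurin assay, with a stated time of 72 h (on this read-out higher numbers stand for weaker inhibition and lower numbers for stronger inhibition), compound 1 `O=C(CCN1CCN(c2ccc([N+](=O)[O-])cc2)CC1)c1ccc(F)cc1` gives 111000 nM and compound 2 `O=C(CCN1CCN(c2ccc(C(F)(F)F)cc2)CC1)c1ccc(F)c(Cl)c1` gives 74500 nM so the two stand within the scatter of each other. Compound 3 `O=C(CCN1CCN(c2ccc([N+](=O)[O-])cc2)CC1)c1ccc(F)c(Cl)c1` differs from compound 2 by nitro in place of trifluoromethyl on an aromatic carbon with nitro in place of trifluoromethyl on an aromatic carbon, para to a large group. Going by the values given here, no measured pair isolates this change. Compound 1, which also carries nitro, gives 111000 nM within the scatter of compound 2, so no step beyond the scatter is expected in this assay for this change. The expected step is a 1.2-fold higher number from compound 2 to compound 3 (0.07 log units; within the scatter) and stays within the scatter. For compound 3 the estimated value is 88000 nM with a range from 45000 nM to 170000 nM for repeat measurements.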

Compound 3, half-maximal inhibitory concentration: 116000 nM
For compound 3 the middle estimate is 1.3-fold (0.12 log units) below the measured one; the measured number falls inside the stated range.
By their numbers in this assay, from the lowest: compounds 2, 1 and 3 (each within the scatter of the next).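

In this assay nitro in place of trifluoromethyl on an aromatic carbon, para to a large group, now reads directly as a 1.6-fold higher number from compound 2 to compound 3 (0.19 log units; within the scatter) and so gives no step beyond the scatter. Chloro in place of hydrogen on an aromatic carbon, with nitro held fixed, reads as a 1.0-fold higher number from compound 1 to compound 3 (0.02 log units; within the scatter) and so does not separate these two compounds either. No measurement here bears on why these values lie so close. Going by these compounds, whether an amine or a carboxylic acid in place of nitro on that aromatic carbon would give a step beyond the scatter stays open. On these data alone, the effect of a longer chain in the core of compound 3 also stays open.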